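Dropping the trifluoromethyl from a weak adenosine A3 ligand

The source may report more compounds than this note shows. Statements on the series, on what has been measured and on what is new or still open speak of the compounds shown alone.

Measured compounds:
- compound 1 `CC(C)(C)Cn1cc2c(Cl)nc(NC(=O)c3ccc(C(F)(F)F)cc3)nc2n1`: in an assay on CHO cells for displacement of a labelled ligand from adenosine receptor A3 (Homo sapiens), read by scintillation counting, with a stated time of 3 h (a higher number here means a weaker inhibitor, a lower number a stronger inhibitor), compound 1 gives 6600 nM.
- compound 2 `CCOC(=O)c1nc(NC(=O)c2ccc(C)cc2)nc2nn(CC(C)(C)C)cc12`: in this assay compound 2 gives 900 nM.
- compound 3 `Cn1cc2c(Cl)nc(N)nc2n1`: for compound 3 this assay reports only a limit, > 100000 nM.

Of the two numbers obtained, compound 1 has the higher one, so it is the weaker binder of that pair: compound 2 has the lower number, a gap beyond the usual scatter. Compound 3 sits at the limit of > 100000 nM in this assay, at which 1 of the 3 values shown sits, and gives no number to compare.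

The next compound, compound 4 `CC(C)(C)Cn1cc2c(Cl)nc(NC(=O)c3ccccc3)nc2n1`, differs from compound 1 in one place: hydrogen in place of trifluoromethyl on an aromatic carbon. The shared core, the amide and the neopentyl chain are kept; only the substituent on the benzoyl ring goes.

Within the data shown here, no measured pair shows this change, so the data give no direction for it. Compound 4 is expected to land near compound 1, at roughly 9000 nM, within a range from 3000 nM to 30000 nM. The step of a 1.4-fold higher number from compound 1 to compound 4 (0.13 log units; within the scatter) is thus estimated to stay within the scatter, with a weak lean toward a slightly higher number.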

Compound 4, inhibition constant: 30300 nM
Compound 4: the middle estimate sits 3.4-fold (0.53 log units) below what was measured; the measured number lies above the stated range.
By their numbers in this assay, from the lowest: compound 2; then compound 1; then compound 4. At a limit, above all of these: compound 3.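

Replacing the trifluoromethyl with hydrogen on the aromatic carbon gives a 4.6-fold higher number from compound 1 to compound 4 (0.66 log units; beyond the scatter) in this assay, the only step shown between compounds that differ in one place. This position, para to a large group, is therefore not indifferent to its substituent: with the shared core, the amide and the neopentyl chain unchanged, compound 4 binds more weakly than compound 1 and trifluoromethyl is the better of the two groups compared here. Nothing measured among these compounds accounts for the direction or size of this step.

Going by these compounds, a single pair cannot show whether any substituent at this place would help or whether the benefit is particular to trifluoromethyl, so the standing of a methoxy group or a nitrile there on the same core remains open. Also open, on these data alone, is whether the step would carry over to a core bearing the ethyl ester of compound 2 in place of the chlorine.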